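This account rests on a few compounds, and the source may have more. Where it says the series, first, only, none or still open, it means among the compounds named here.

Three compounds share one core and differ only in the group attached to a nitrogen on an aromatic ring. In a functional assay on HCC78 cells (Homo sapiens) for antiproliferative activity, read by MTT assay, with a stated time of 48 h (a lower number here means a stronger inhibitor, a higher number a weaker inhibitor), compound 1 `Cc1ccc(CNC(=O)c2cccc(C(C)Oc3ccnc(Nc4cnn(C5CCN(C)CC5)c4)c3)c2)cc1` gives 8100 nM, compound 2 `Cc1ccc(CNC(=O)c2cccc(C(C)Oc3ccnc(Nc4cn(C)nc4C)c3)c2)cc1` gives 17500 nM, and compound 3 `Cc1ccc(CNC(=O)c2cccc(C(C)Oc3ccnc(Nc4cnn(CC(C)(C)O)c4)c3)c2)cc1` gives 49700 nM, the highest of the three numbers, since a 6.1-fold higher number from compound 1 to compound 3 (0.79 log units; beyond the scatter) and a 2.8-fold higher number from compound 2 to compound 3 (0.45 log units; beyond the scatter). Compound 4 `Cc1ccc(CNC(=O)c2cccc(C(C)Oc3ccnc(Nc4nc5ccccc5[nH]4)c3)c2)cc1` carries a different change: 1H-benzimidazol-2-yl in place of 1-(2-hydroxy-2-methylpropyl)-1H-pyrazol-4-yl on a nitrogen on an aromatic ring. Going by the values given here, no measured step swaps the whole five-membered ring for a fused ring system; the steps seen, including a 2.2-fold higher number from compound 1 to compound 2 (0.33 log units; beyond the scatter), only exchange substituents on the same ring, so they bear weakly on this change. A modest move in either direction is therefore expected, and the estimate for compound 4 is 25000 nM in this assay, within 5000 nM to 120000 nM, which means an expected step of a 2.0-fold lower number from compound 3 to compound 4 (0.30 log units; within the scatter).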

Compound 4, half-maximal inhibitory concentration: > 100000 nM
Compound 4 gave a limit, no number; the forecaster's own chance of this, stated with the estimate: 10%; middle value at least 4.0-fold (0.60 log units) away from the limit.
By their numbers in this assay, from the lowest: compound 1; then compound 2; then compound 3. At a limit, above all of these: compound 4.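

In this assay, compound 4 gives a limit and not a number: the limit of > 100000 nM in this assay, at which 1 of the 4 values shown sits. Placing 1H-benzimidazol-2-yl on this nitrogen gives an at least 12-fold higher number from compound 1 to compound 4 (1.09 log units; beyond the scatter) and an at least 5.7-fold higher number from compound 2 to compound 4 (0.75 log units; beyond the scatter), so this fused swap can cost far more than the substituent exchanges among compounds 1, 2 and 3 did. The third comparison, an at least 2.0-fold higher number from compound 3 to compound 4 (0.30 log units; that floor lies within the scatter), does not by itself establish a loss.

From the compounds shown here alone, how far compound 4 really lies past its limit remains open. So does whether a dimethylaminoethyl group or a carboxylic acid on the 1H-benzimidazol-2-yl ring would bring back a measurable number.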